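Swapping a Methyl Ether for an Oxolanyl Ether

A few compounds are considered here, and "the series" means these few. Any claim that something is new, unique, unknown or untested is made for them only; others in the source may bear on it.

Compound 3 `COc1ccc(/C=C/C(=O)Nc2cc3c(Nc4ccc(F)c(Cl)c4)ncnc3cc2OC)cc1` has no number in a functional assay on MCF7 cells (Homo sapiens) for cytotoxicity, read by MTT assay, with a stated time of 72 h; a lower number here means a stronger inhibitor, a higher number a weaker inhibitor; compound 3 is recorded there as "not active" (no number reported), so it stands without a measured value among the compounds here. Compound 4 `COc1ccc(/C=C/C(=O)Nc2cc3c(Nc4ccc(F)c(Cl)c4)ncnc3cc2O[C@H]2CCOC2)cc1` differs from it in one change: oxolan-3-yl in place of methyl on an oxygen on an aromatic ring. Two measured compounds carry the same oxolanyl ether: compound 1 `COc1cc(/C=C/C(=O)Nc2cc3c(Nc4ccc(F)c(Cl)c4)ncnc3cc2O[C@H]2CCOC2)cc(OC)c1` gives 30300 nM in this assay, and compound 2 `N#Cc1ccc(/C=C/C(=O)Nc2cc3c(Nc4ccc(F)c(Cl)c4)ncnc3cc2O[C@H]2CCOC2)cc1` gives 9830 nM. Going by the values given here, the only measured step, a 3.1-fold lower number from compound 1 to compound 2 (0.49 log units; beyond the scatter), exchanges one aryl group for another and leaves the ether untouched, so it does not bear directly on the step from compound 3 to compound 4; no measured step does. What the numbers show is that both compounds with the oxolanyl ether fall in a weak range, while compound 3 with the methyl ether returned no value at all. Compound 4 is therefore expected to sit in that weak range, with an estimate of 20000 nM and a span from 6000 nM to 60000 nM, and a real chance that it too returns no number.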

Compound 4, half-maximal inhibitory concentration: 5070 nM
Beside the measured number, compound 4's estimate is 3.9-fold (0.60 log units) above it; the whole stated range lies above it.
By their numbers in this assay, from the lowest: compounds 4 and 2 (each within the scatter of the next); then compound 1.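

Compound 4 carries a number in this assay where compound 3, with the methyl ether and the same 4-methoxyphenyl group, is recorded as "not active", so with the oxolan-3-yl ether this aryl group gives a measurable result, although the step between the two cannot be read. Among the oxolan-3-yl ethers, the aryl group matters only in part: the printed step is a 1.9-fold lower number from compound 2 to compound 4 (0.29 log units; within the scatter) for methoxy in place of cyano, whereas 4-methoxyphenyl in place of 3,5-dimethoxyphenyl gives a 6.0-fold lower number from compound 1 to compound 4 (0.78 log units; beyond the scatter) and so separates these two compounds. Nothing shown explains these results.

The compounds shown leave open how the other mirror-image form of the oxolan-3-yl ether would read, and whether a longer chain ending in an amine on that oxygen would behave like the oxolan-3-yl group. They also leave open how a carboxylic acid on the aromatic ring would compare with methoxy and cyano.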